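Imidazole N-alkyl extension in a benzimidazole-piperazine series

The source may hold more compounds than are shown below. What is called first, only, known or untested is meant among the compounds shown, and "the series" means these compounds.

Measured compounds:
compound 1 `Cc1nc(C)c(CN2CCN(c3cccc4[nH]c(-c5ccc(C(C)(C)C)cc5)nc34)CC2)o1` — 740 nM
compound 2 `CCc1nc(C)c(CN2CCN(c3cccc4[nH]c(-c5ccc(C(C)(C)C)cc5)nc34)CC2)s1` — 120 nM
compound 3 `CCn1cc(CN2CCN(c3cccc4[nH]c(-c5ccc(C(C)(C)C)cc5)nc34)CC2)nc1C` — 51 nM

In an assay on isolated protein for displacement of a labelled ligand from Gonadotropin-releasing hormone receptor (Rattus norvegicus) (a higher number here means a weaker inhibitor, a lower number a stronger inhibitor), compound 3 holds the lowest number of the three. The ring swaps that reach it are a 15-fold lower number from compound 1 to compound 3 (1.16 log units; beyond the scatter) and a 2.4-fold lower number from compound 2 to compound 3 (0.37 log units; beyond the scatter); the remaining comparison is a 6.2-fold lower number from compound 1 to compound 2 (0.79 log units; beyond the scatter). Compound 4 `CCCn1cc(CN2CCN(c3cccc4[nH]c(-c5ccc(C(C)(C)C)cc5)nc34)CC2)nc1C` differs from compound 3 only by methyl in place of hydrogen on a saturated chain carbon, two bonds along the chain from an aromatic nitrogen. Going by the values given here, none of the measured steps touches this chain: each exchanges the whole heteroaryl ring, leaving the ethyl untouched, so no direct guide to the size or direction of this change exists. With nothing to push it either way, the step is expected to stay within scatter: compound 4 is estimated at 45 nM (range 18 nM to 120 nM), that is a 1.1-fold lower number from compound 3 to compound 4 (0.05 log units; within the scatter).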

Compound 4, half-maximal inhibitory concentration: 41 nM
Compound 4: the middle estimate sits 1.1-fold (0.04 log units) above what was measured; low and high end bracket the measured number.
By their numbers in this assay, from the lowest: compounds 4 and 3 (each within the scatter of the next); then compound 2; then compound 1.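

In this assay, ethyl to propyl on the imidazole gives a 1.2-fold lower number from compound 3 to compound 4 (0.09 log units; within the scatter), so this chain takes the added methyl with no change beyond the scatter. The 2-methyl-1-propyl-1H-imidazol-4-yl group also keeps the imidazole's margin over the other two rings, with a 2.9-fold lower number from compound 2 to compound 4 (0.47 log units; beyond the scatter) and an 18-fold lower number from compound 1 to compound 4 (1.26 log units; beyond the scatter). No supporting data explain why the number holds at this chain.

As far as these compounds go, it remains open whether a longer chain such as butyl, or a chain ending in an amine or a carboxylic acid, would be accepted in place of propyl.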